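Piperazine in Place of the Open Chain

The source may report more compounds than this note shows. Statements on the series, on what has been measured and on what is new or still open speak of the compounds shown alone.

Compound 1 `COc1cc(C)c(S(=O)(=O)N(C)CCOCC(=O)N2CCC(C3CCN(C)CC3)CC2)c(C)c1` gives 9 in a functional assay on Umbilical vein for antagonist activity at B1 bradykinin receptor (Homo sapiens), using Schild analysis, with a stated time of 30 min; a higher number here means a more potent compound, by a factor of ten per unit of this negative logarithm, a lower number a less potent compound.
Compound 2 `COc1cc(C)c(S(=O)(=O)N(C)CCOCC(=O)N2CCC(C(C)(C)CN(C)C)CC2)c(C)c1` gives 7.5 in this assay.

Compound 2 stands lowest of the two numbers in this assay. Within the data shown here, the single step reaching it, a number 1.50 log units lower from compound 1 to compound 2 (beyond the scatter), was a large loss when a ring gave way to an open chain. Compound 3 `COc1cc(C)c(S(=O)(=O)N(C)CCOCC(=O)N2CCC(N3CCN(C(C)C)CC3)CC2)c(C)c1` differs from compound 2 by 4-isopropylpiperazin-1-yl in place of 1-((dimethylamino)methyl)-1-methylethyl on a saturated ring carbon. That one step bears on the change: a six-membered non-aromatic ring with two hetero atoms comes back, so a recovery toward compound 1 is expected, though not necessarily the whole way. Compound 3 is therefore estimated at 8.5, within 7.5 to 9.5. The expected step is a number 1.00 log units higher from compound 2 to compound 3 (beyond the scatter).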

Compound 3, negative logarithm of the antagonist equilibrium constant: 8.5
Beside the measured number, compound 3's estimate shows no gap at the digits printed; low and high end bracket the measured number.
By their numbers in this assay, from the lowest: compound 2; then compound 3; then compound 1.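

With 4-isopropylpiperazin-1-yl on this saturated ring carbon, the result in this assay is a number 1.00 log units higher from compound 2 to compound 3 (beyond the scatter) and so regains most of what the open chain lost. The same group still falls short of 1-methylpiperidin-4-yl, at a number 0.50 log units lower from compound 1 to compound 3 (beyond the scatter) and so a ring here restores much of the potency, though the two ring groups are not equal. From the compounds shown here alone, whether the remaining gap follows from the second ring nitrogen or from the isopropyl group stays open, and a 4-methylpiperazin-1-yl group would bear on that. No measurement shown here explains these differences.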